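From Nitro to Chloro on a Growth-Inhibiting Series

This account rests on a few compounds, and the source may have more. Where it says the series, first, only, none or still open, it means among the compounds named here.

Measured in a functional assay on HT-29 cells (Homo sapiens) for cytotoxicity, read by sulforhodamine B assay; a higher number here means a weaker inhibitor of growth, a lower number a stronger inhibitor of growth:
- compound 1 `CC1=CC[C@@H]([C@@](C)(O)CCCC(C)(C)NC(=S)N/N=C\c2ccc(O)cc2)CC1`: 8150 nM
- compound 2 `CC1=CC[C@@H]([C@@](C)(O)CCCC(C)(C)NC(=S)N/N=C\c2ccc(N(C)C)cc2)CC1`: 27700 nM
- compound 3 `CC1=CC[C@@H]([C@@](C)(O)CCCC(C)(C)NC(=S)N/N=C\c2ccc([N+](=O)[O-])cc2)CC1`: 12300 nM

Compound 3 holds the middle place among these three numbers, though its gap to one neighbour is only scatter: a 1.5-fold higher number from compound 1 to compound 3 (0.18 log units; within the scatter). Its gap to the other is larger: a 2.3-fold lower number from compound 2 to compound 3 (0.35 log units; beyond the scatter).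

The next compound, compound 4 `CC1=CC[C@@H]([C@@](C)(O)CCCC(C)(C)NC(=S)N/N=C\c2ccc(Cl)cc2)CC1`, keeps the shared core and changes one group: chloro in place of nitro on an aromatic carbon. In short, this is chloro in place of nitro on an aromatic carbon.

Going by the values given here, no chloro compound has been measured yet, so the guide is the other swaps at this same place. The largest of them was still modest: a 3.4-fold higher number from compound 1 to compound 2 (0.53 log units; beyond the scatter). The swap of hydroxy for nitro stayed within the scatter, as shown above. A step beyond the scatter is therefore not expected in this assay, and no direction is predicted. The estimate amounts to a 1.1-fold lower number from compound 3 to compound 4 (0.05 log units; within the scatter).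

The estimated value for compound 4 is 11000 nM, with an expected range of 5000 nM to 24000 nM.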

Compound 4, concentration for 50% growth inhibition: 7350 nM
Compound 4: the middle estimate sits 1.5-fold (0.18 log units) above what was measured, and the stated range covers the measured number.
By their numbers in this assay, from the lowest: compounds 4, 1 and 3 (each within the scatter of the next); then compound 2.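

In this assay the swap of nitro for chloro gives a 1.7-fold lower number from compound 3 to compound 4 (0.22 log units; within the scatter) and so shows that a group with hydrogen-bond acceptors can give way to one with none at this aromatic carbon without a step beyond the scatter. Set against hydroxy, chloro shows a 1.1-fold lower number from compound 1 to compound 4 (0.04 log units; within the scatter) and joins hydroxy and nitro as one cluster, while the largest step at this place, though still modest, is a 3.8-fold lower number from compound 2 to compound 4 (0.58 log units; beyond the scatter) and it leaves the dimethylamino compound as the one exception. Nothing measured here gives a reason for these numbers.

The compounds shown leave open whether a carboxylic acid, a primary amine or a longer chain on this aromatic carbon would fall inside that cluster. They also leave open what a change elsewhere on the shared core would do.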